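This account rests on a few compounds, and the source may have more. Where it says the series, first, only, none or still open, it means among the compounds named here.

Measured compounds in an assay on isolated protein for inhibition of Apoptosis regulator Bcl-2/Bcl-2 homologous antagonist/killer (Homo sapiens), read by surface plasmon resonance, with a stated time of 1 h; a lower number here means that less compound is needed, a higher number that more compound is needed for the effect:
compound 1 `CCS(=O)(=O)NC(=O)c1ccc(N2CCN(Cc3ccccc3-c3ccc(Cl)cc3)CC2)cc1` gives 5310 nM
compound 2 `CC1(C)C2CC[C@@]1(CS(=O)(=O)NC(=O)c1ccc(N3CCN(Cc4ccccc4-c4ccc(Cl)cc4)CC3)cc1)C(=O)C2` gives 1470 nM
compound 3 `CC1(C)[C@]2(C)CC[C@@H](CS(=O)(=O)NC(=O)c3ccc(N4CCN(Cc5ccccc5-c5ccc(Cl)cc5)CC4)cc3)[C@@]1(C)C2` gives 420 nM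

Compound 2 stands second highest of the three numbers; its nearest neighbour is compound 3, reached by a 3.5-fold lower number from compound 2 to compound 3 (0.54 log units; beyond the scatter), and the furthest is compound 1, from which a 3.6-fold lower number from compound 1 to compound 2 (0.56 log units; beyond the scatter) leads to it.

Compound 4 `CS(=O)(=O)NC(=O)c1ccc(N2CCN(Cc3ccccc3-c3ccc(Cl)cc3)CC2)cc1` has not yet been run in this assay. Against compound 2 the change is a hydrogen atom in place of a group of 10 heavy atoms (9 carbon, 1 oxygen; 2 five-membered non-aromatic rings of carbon only), on a saturated chain carbon bound to a sulfonyl sulfur.

For the measured compounds named here, the step that bears on this is the reverse of the one from compound 1, where a 3.6-fold lower number from compound 1 to compound 2 (0.56 log units; beyond the scatter) was seen on adding the group at the same place. Compound 4 carries even less than compound 1 at that carbon, so a higher number than compound 2 is expected, of about the size of that step or somewhat beyond it.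

The expected step is a 4.8-fold higher number from compound 2 to compound 4 (0.68 log units; beyond the scatter), so for compound 4 the estimate is 7000 nM, in the range 3000 nM to 16000 nM.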

Compound 4, half-maximal effective concentration: 8620 nM
Compound 4: middle estimate off by 1.2-fold (0.09 log units), on the low side, and the stated range covers the measured number.
By their numbers in this assay, from the lowest: compound 3; then compound 2; then compounds 1 and 4 (each within the scatter of the next).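

In this assay, hydrogen in place of methyl on the saturated chain carbon bound to a sulfonyl sulfur gives no separable change (a 1.6-fold higher number from compound 1 to compound 4 (0.21 log units; within the scatter)), so the two smallest substituents here read alike. Against that level, only the two large groups stand apart (a 5.9-fold higher number from compound 2 to compound 4 (0.77 log units; beyond the scatter); a 21-fold higher number from compound 3 to compound 4 (1.31 log units; beyond the scatter)), which places the whole span seen so far at this position on those two groups.

Open, on these data alone, is what lies between methyl and these groups: whether a longer chain, a cyclohexyl group or a benzyl group at this carbon already lowers the number. Nothing measured on hand explains the steps.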